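Stepping from compound 2 to compound 4

The compounds below may be only part of what the source reports. "The series", "measured", "known", "first", "only" and "open" are said of these compounds alone.

compound 1 `COC(=O)c1ccc(-n2cc(CCCNC(=O)c3ccc(C)cc3)nn2)cc1`: > 100000 nM (a limit)
compound 2 `COC(=O)c1ccc(-n2cc(CCCNC(=S)c3ccc(C)cc3)nn2)cc1`: > 100000 nM (a limit)
compound 3 `COC(=O)c1ccc(-n2cc(CCCNC(=S)Nc3ccc(C)cc3)nn2)cc1`: 46500 nM

In a functional assay on A549 cells (Homo sapiens) for inhibition, read by MTT assay, with a stated time of 72 h (a lower number here means a stronger inhibitor, a higher number a weaker inhibitor), compound 2 stands only at a limit, > 100000 nM. This is the limit of > 100000 nM in this assay, at which 2 of the 3 values shown sit. Compound 4 `COC(=O)c1ccc(-n2cc(CCCNc3ccc(C)cc3)nn2)cc1` differs from it by a group of 7 heavy atoms (7 carbon; one six-membered aromatic ring of carbon only) in place of a group of 9 heavy atoms (8 carbon, 1 sulfur; one six-membered aromatic ring of carbon only), on an amine nitrogen. Among the compounds with values here, two measured steps bear on this change. One is a step that the two limits leave unreadable from compound 1 to compound 2, which gives no size. The other is an at least 2.1-fold lower number from compound 2 to compound 3 (0.33 log units; beyond the scatter), a modest change made on the thiocarbonyl carbon, which compound 4 no longer has, so it is only a loose guide. A similarly modest move to a lower number is expected in this assay, though compound 4 may also remain at a limit. The expected step is an at least 1.4-fold lower number from compound 2 to compound 4 (0.15 log units; that floor lies within the scatter). For compound 4 the estimated value is 70000 nM, with an expected range of 25000 nM to 150000 nM.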

Compound 4, half-maximal inhibitory concentration: > 100000 nM
Compound 4 was reported as a limit; the forecaster's own chance of this, stated with the estimate: 40%; at least 1.4-fold (0.15 log units) between middle value and limit.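

Compound 4 gives only a limit, > 100000 nM, and its steps from compound 1 and compound 2, also limits, cannot be read. The compounds shown leave open how large any difference among these three is.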